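A few compounds are considered here, and "the series" means these few. Any claim that something is new, unique, unknown or untested is made for them only; others in the source may bear on it.

Compound 1 `Cc1nc(NC(=O)c2ccccc2)sc1C(=O)/C=C/c1ccc(F)cc1` gives 140 nM in an assay for inhibition of Polyunsaturated fatty acid 5-lipoxygenase (Homo sapiens), read by spectrophotometry, in the presence of a further agent that is not named here (a lower number here means a stronger inhibitor, a higher number a weaker inhibitor), the lowest of the three numbers recorded. Compound 2 `COc1ccc(C(=O)Nc2nc(C)c(C(=O)/C=C/c3ccc(F)cc3)s2)cc1` gives 560 nM and compound 3 `Cc1ccc(/C=C/C(=O)c2sc(NC(=O)c3ccc(F)cc3)nc2C)cc1` gives 540 nM. Within the data shown here, the one single-point step available is a 4.0-fold higher number from compound 1 to compound 2 (0.60 log units; beyond the scatter), a change on the benzamide side of the shared core. Compound 4 `Cc1nc(NC(=O)c2ccccc2)sc1C(=O)/C=C/c1ccc(N(C)C)cc1` differs from compound 1 by dimethylamino in place of fluoro on an aromatic carbon, on an aromatic carbon of a six-membered aromatic ring of carbon only. Among the measured compounds shown here, no measured step touches this ring alone, so the only guide is that the one change tried so far weakened inhibition modestly. A weakening of similar or smaller size is expected, a 2.3-fold higher number from compound 1 to compound 4 (0.36 log units; beyond the scatter). Compound 4 is therefore estimated at 320 nM, within the range 100 nM to 1200 nM.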

Compound 4, half-maximal inhibitory concentration: 640 nM
For compound 4 the middle estimate is 2.0-fold (0.30 log units) below the measured one, within the range that was stated.
By their numbers in this assay, from the lowest: compound 1; then compounds 3, 2 and 4 (each within the scatter of the next).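

The ring carrying the fluoro group had not been touched by any earlier step, and here it proves sensitive in this assay, with a 4.6-fold higher number from compound 1 to compound 4 (0.66 log units; beyond the scatter) on going from 4-fluorophenyl to 4-(dimethylamino)phenyl. So the benzamide side is not the only part of compound 1 where a single change weakens inhibition beyond the scatter. Nothing available explains this loss. The compounds shown leave open whether the loss follows from removing fluoro or from introducing dimethylamino. A primary amine or a chloro group at this place would help separate the two.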